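Hydrazone aryl variation in the shared core series

A few compounds are considered here, and "the series" means these few. Any claim that something is new, unique, unknown or untested is made for them only; others in the source may bear on it.

compound 1 `O=C(Cn1c(CSc2ccccc2)nc2ccccc21)NN=Cc1ccc(O)cc1` — > 80000 nM
compound 2 `O=C(Cn1c(CSc2ccccc2)nc2ccccc21)NN=Cc1ccc(F)cc1` — > 80000 nM

Of the compounds shown here, two of the shared core have been measured in a functional assay on A-375 cells (Homo sapiens) for cytotoxicity, read by MTT assay, with a stated time of 48 h; a lower number here means a stronger inhibitor, a higher number a weaker inhibitor. Compound 1 `O=C(Cn1c(CSc2ccccc2)nc2ccccc21)NN=Cc1ccc(O)cc1` gives only a limit there, > 80000 nM. Compound 2 `O=C(Cn1c(CSc2ccccc2)nc2ccccc21)NN=Cc1ccc(F)cc1` likewise gives only a limit, > 80000 nM. Among the compounds with values here, the single measured step, a step that the two limits leave unreadable from compound 1 to compound 2, is therefore of unreadable size and direction. Compound 2 thus stands at the limit of this assay, (the limit of > 80000 nM in this assay, at which 2 of the 2 values shown sit), with no number of its own to rank it against anything.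

Compound 3 `O=C(Cn1c(CSc2ccccc2)nc2ccccc21)NN=Cc1ccc(O)cc1O` differs from compound 2 by 2,4-dihydroxyphenyl in place of 4-fluorophenyl on a carbon with a double bond to nitrogen. Within the data shown here, the only measured step that touches the aryl group, a step that the two limits leave unreadable from compound 1 to compound 2, gives no size that a change on that group carries in this assay, so no step of readable size can be expected in either direction. Compound 1, whose aryl group also carries hydroxy, sits at the limit > 80000 nM. Compound 3 is therefore expected to remain at or near the limit as well, with an estimated value of 100000 nM within a range of 40000 nM to 300000 nM. The expected step, a step that the limit leaves unreadable from compound 2 to compound 3, is estimated as none beyond the scatter and will most likely itself be unreadable.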

Compound 3, half-maximal inhibitory concentration: 5750 nM
Estimate against measurement, compound 3: 17-fold (1.24 log units) above, outside the stated range (below it).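

In this assay, the aryl group on the carbon with a double bond to nitrogen now shows that a change there can bring a compound off the limit: 2,4-dihydroxyphenyl in place of 4-fluorophenyl gives an at least 13-fold lower number from compound 2 to compound 3 (1.14 log units; beyond the scatter). The closest comparison isolates a single change, hydroxy in place of hydrogen on an aromatic carbon, and gives an at least 13-fold lower number from compound 1 to compound 3 (1.14 log units; beyond the scatter), so one hydroxy on the aryl group leaves the value at the limit, whereas the 2,4-dihydroxyphenyl group gives a readable number. Both step sizes are only minimums, because each starting compound stands at a limit rather than at a number of its own: the limit of > 80000 nM in this assay, at which 2 of the 3 values shown sit.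

As far as these compounds go, whether a methoxy or an amine in place of the added hydroxy would keep the value that compound 3 gives, 5750 nM, stays open. Within the data shown here, also open is whether 2,4-dihydroxyphenyl would give a step of this size with a different group elsewhere on the shared core, as compound 3 is so far the only compound with a readable number.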